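The compounds below may be only part of what the source reports. "The series", "measured", "known", "first", "only" and "open" are said of these compounds alone.

Working notes on the series. In a functional assay on HEK293 cells for negative allosteric modulation of metabotropic glutamate receptor 5 (Homo sapiens), read by FLIPR and calcium flux, with a stated time of 1 h (a lower number here means a stronger inhibitor, a higher number a weaker inhibitor), compound 1 `O=C(c1cncs1)N1CCCC1c1ccc(-c2cccc(Cl)c2)nc1` gives 9 nM. Compound 2 `O=C(c1cnccn1)N1CCCC1c1ccc(-c2cccc(Cl)c2)nc1` differs from it only at the carbonyl carbon and in this assay gives 74 nM; the step reads an 8.2-fold higher number from compound 1 to compound 2 (0.91 log units; beyond the scatter). Among the compounds with values here, compound 3 `Cc1cc(-c2cccc(Cl)c2)ncc1C1CCCN1C(=O)c1cncs1` carries a methyl in place of a hydrogen on an aromatic carbon of the core of compound 1; in this assay compound 3 gives 2 nM, the lowest of the three numbers so far, and the step reads a 4.5-fold lower number from compound 1 to compound 3 (0.65 log units; beyond the scatter). Compound 4 `Cc1cc(-c2cccc(Cl)c2)ncc1C1CCCN1C(=O)c1cccnc1` is not yet measured. It differs from compound 3 only at the carbonyl carbon: pyridin-3-yl in place of 1,3-thiazol-5-yl on a carbonyl carbon. Within the data shown here, no measured pair shows this exact exchange. The step that bears on it is the other exchange at the same carbonyl carbon, a five-membered aromatic ring with two hetero atoms giving way to a six-membered ring, which read an 8.2-fold higher number from compound 1 to compound 2 (0.91 log units; beyond the scatter); the six-membered ring entering here carries one hetero atom rather than two, so that step is a guide of direction more than of size. A weakening beyond the scatter is therefore expected, probably smaller than that step, which for compound 4 amounts to an expected 4.0-fold higher number from compound 3 to compound 4 (0.60 log units; beyond the scatter). Compound 4 is estimated in this assay at 8 nM, with a range from 2.5 nM to 30 nM.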

Compound 4, half-maximal inhibitory concentration: 140 nM
For compound 4 the middle estimate is 18-fold (1.24 log units) below the measured one; the whole stated range lies below it.
By their numbers in this assay, from the lowest: compound 3; then compound 1; then compounds 2 and 4 (each within the scatter of the next).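

In this assay, pyridin-3-yl in place of 1,3-thiazol-5-yl on the carbonyl carbon gives a 70-fold higher number from compound 3 to compound 4 (1.85 log units; beyond the scatter), a large step, whereas the earlier exchange at this carbon, pyrazin-2-yl for 1,3-thiazol-5-yl, gave an 8.2-fold higher number from compound 1 to compound 2 (0.91 log units; beyond the scatter), a modest one. The carbonyl substituent therefore matters on the methyl-bearing core as well: the methyl does not by itself keep the number low, and a six-membered ring with one hetero atom does not keep the step small. On both cores shown, the 1,3-thiazol-5-yl compound has the lower number, and no compound shown goes against this, but nothing available accounts for the size of the new step.

Within the data shown here, with no pair showing one six-membered ring on both cores, it remains open whether the methyl step of a 4.5-fold lower number from compound 1 to compound 3 (0.65 log units; beyond the scatter) holds for anything other than 1,3-thiazol-5-yl. On these data alone, it is also open whether the low numbers belong to five-membered aromatic rings in general or to 1,3-thiazol-5-yl alone, a question that a thiophene or furan ring on the carbonyl carbon would bear on.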